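This account rests on a few compounds, and the source may have more. Where it says the series, first, only, none or still open, it means among the compounds named here.

Two compounds of the series have numbers in a functional assay for agonist activity at growth hormone secretagogue receptor type 1 (Homo sapiens), read by FLIPR; on this read-out lower numbers stand for an effect already at smaller amounts and higher numbers for an effect only at larger amounts of compound. Compound 1 `CCOc1ccc(N2C[C@@H](C)N[C@@H](C)C2)cc1NS(=O)(=O)c1ccc(-c2ccccn2)s1` gives 39.8 nM in this assay, and compound 2 `COc1ccc(N2C[C@@H](C)N[C@@H](C)C2)cc1NS(=O)(=O)c1ccc(-c2ccccc2)cc1` gives 6.31 nM. Of the two, compound 2 holds the lower number; the number for compound 1 is higher, and the gap lies beyond the usual scatter of this assay. Compound 3 `COc1ccc(F)c(-c2ccc(S(=O)(=O)Nc3cc(N4C[C@@H](C)N[C@@H](C)C4)ccc3OC)cc2)c1` is not yet measured. It differs from compound 2 in one place: 2-fluoro-5-methoxyphenyl in place of phenyl on an aromatic carbon. Within the data shown here, no measured pair shows this change, so there is no earlier step to set its size or direction from, and the two measured numbers alone say nothing about it. The expected step in this assay is a 1.0-fold lower number from compound 2 to compound 3 (0.00 log units; within the scatter), that is, none beyond the scatter in either direction. Compound 3 is accordingly estimated at 6.3 nM, with a range from 2 nM to 20 nM.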

Compound 3, half-maximal effective concentration: 0.398 nM
Estimate against measurement, compound 3: 16-fold (1.20 log units) above, outside the stated range (below it).
By their numbers in this assay, from the lowest: compound 3; then compound 2; then compound 1.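

In this assay this position, on an aromatic carbon para to a large group, responds strongly to substitution: 2-fluoro-5-methoxyphenyl in place of phenyl gives a 16-fold lower number from compound 2 to compound 3 (1.20 log units; beyond the scatter) for this single change. Among these compounds, compound 1 could not show this, since it differs from compound 2 in more than one place, so this is the first one-place comparison and it shows that the larger substituted ring is accepted here. No evidence on hand bears on the reason for the size of this step.

As far as these compounds go, the fluorine and the methoxy enter together, so the share of each stays open, and plain 2-fluorophenyl and 3-methoxyphenyl would separate them. Also open, from the compounds shown here alone, is how a carboxylic acid or an aminomethyl group on this ring would read, and whether the same replacement carries over to the core of compound 1.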